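A few compounds are considered here, and "the series" means these few. Any claim that something is new, unique, unknown or untested is made for them only; others in the source may bear on it.

Measured in a functional assay on NIH3T3 cells (Mus musculus) for inhibition, read by MTT assay, with a stated time of 72 h; on this read-out higher numbers stand for weaker inhibition and lower numbers for stronger inhibition:
- compound 1 `C=C1CC[C@H]2[C@@](C)(CC[C@@H](O)[C@@]2(C)C(=O)OCc2ccccn2)[C@@H]1CCC1=CCOC1=O`: 79800 nM
- compound 2 `C=C1CC[C@H]2[C@@](C)(CC[C@@H](O)[C@@]2(C)C(=O)OC)[C@@H]1/C=C/C1=CCOC1=O`: 111000 nM
- compound 3 `C=C1CC[C@H]2[C@@](C)(CC[C@@H](O)[C@@]2(C)C(=O)OCc2ccccc2)[C@@H]1/C=C/C1=CCOC1=O`: 13600 nM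

Compound 3 has the lowest number of the three. The next structure, compound 4 `C=C1CC[C@H]2[C@@](C)(CC[C@@H](O)[C@@]2(C)C(=O)OCc2ccccn2)[C@@H]1/C=C/C1=CCOC1=O`, differs from it by one change: pyridin-2-yl in place of phenyl on a saturated chain carbon bound to an oxygen next to a carbonyl group. Among the measured compounds shown here, no measured step swaps one of these rings for the other. The closest evidence is an 8.2-fold lower number from compound 2 to compound 3 (0.91 log units; beyond the scatter), seen when phenyl replaced hydrogen at that same carbon. Compound 4 keeps an aromatic ring there, so much of that gain may remain. Compound 1, which carries the same (pyridin-2-yl)methyl group but differs elsewhere, gives 79800 nM, a hint towards weaker inhibition. A modest loss in this assay is therefore expected, with a 2.1-fold higher number from compound 3 to compound 4 (0.31 log units; beyond the scatter) as the estimated step. Compound 4 is estimated at 28000 nM, with an expected range of 10000 nM to 80000 nM.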

Compound 4, half-maximal inhibitory concentration: 80200 nM
Compound 4: middle estimate off by 2.9-fold (0.46 log units), on the low side; the whole stated range lies below it.
By their numbers in this assay, from the lowest: compound 3; then compounds 1, 4 and 2 (each within the scatter of the next).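

At a saturated chain carbon bound to an oxygen next to a carbonyl group, pyridin-2-yl does not behave like phenyl: a 5.9-fold higher number from compound 3 to compound 4 (0.77 log units; beyond the scatter) shows the gain from phenyl is lost, and a 1.4-fold lower number from compound 2 to compound 4 (0.14 log units; within the scatter) puts pyridin-2-yl level with hydrogen there. With pyridin-2-yl in place, changing the group on the saturated ring carbon gives a 1.0-fold higher number from compound 1 to compound 4 (0.00 log units; within the scatter) in this assay, so that change shows no effect. Nothing measured here explains the loss.

Still open, as far as these compounds go, is how pyridin-3-yl, pyridin-4-yl or an aminophenyl group would behave at that carbon.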